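Hydroxymethyl on the Core: Expected Free Fraction of Compound 4

The source may report more compounds than this note shows. Statements on the series, on what has been measured and on what is new or still open speak of the compounds shown alone.

Measured compounds:
- compound 1 `C[C@H](c1ccc(-c2cc(Cl)ccc2-c2nc(=O)o[nH]2)cc1)N(CC1CC1)c1nc2c(C(=O)O)cccc2o1`: 0.000108
- compound 2 `CCCCN(c1nc2ccccc2o1)[C@H](C)c1ccc(-c2ccccc2-c2nnn[nH]2)cc1`: 0.000713
- compound 3 `C[C@H](c1ccc(-c2ccccc2-c2nc(=O)o[nH]2)cc1)N(CC1CC1)c1nc2c(C(=O)O)cccc2o1`: 0.0000851

In an ADME assay on the whole organism (plasma, Macaca fascicularis) for protein binding, read by LC-MS, using equilibrium dialysis and cassette dosing, with a stated time of 24 h, at a dose of 1 mg/kg by the oral route (on this read-out higher numbers stand for a larger free fraction and lower numbers for a smaller free fraction), compound 2 gives 0.000713, the highest of the three numbers; compound 1 gives 0.000108 and compound 3 gives 0.0000851, both beyond the scatter below compound 2. Compound 4 `CCCCN(c1nc2c(CO)cccc2o1)[C@H](C)c1ccc(-c2ccccc2-c2nnn[nH]2)cc1` is not yet measured. It differs from compound 2 in one place: hydroxymethyl in place of hydrogen on an aromatic carbon, on an aromatic carbon of the shared core.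

Within the data shown here, only one measured step exists, a 1.3-fold lower number from compound 1 to compound 3 (0.10 log units; within the scatter), and it concerns a different place, the chloro on the phenyl ring, so it says nothing direct about a hydroxymethyl on the core. Compounds 1 and 3 carry a carboxylic acid where compound 2 carries hydrogen, but they differ from compound 2 in other places too, so their lower values cannot be traced to that position alone. Among the measured compounds shown here, no measured step therefore bears on the change to compound 4, and the expected step in this assay is small, with its direction uncertain. The estimate for compound 4 is 0.001, in a range from 0.0004 to 0.0025, which is expected to mean a 1.4-fold higher number from compound 2 to compound 4 (0.15 log units; within the scatter).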

Compound 4, unbound fraction: 0.00112
Compound 4: middle estimate off by 1.1-fold (0.05 log units), on the low side; the measured number falls inside the stated range.
By their numbers in this assay, from the lowest: compounds 3 and 1 (each within the scatter of the next); then compounds 2 and 4 (each within the scatter of the next).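

In this assay, among these compounds, the first measured step at this position runs a 1.6-fold higher number from compound 2 to compound 4 (0.20 log units; within the scatter) and lies within the usual scatter, so compound 2 and compound 4 cannot be told apart on this read-out. The earlier compounds shown here could not show this, since none of them formed a one-place pair with compound 2, and the values of compound 1 and compound 3 could not be traced to this position alone. Here, a hydroxymethyl in place of hydrogen on this aromatic carbon, ortho to a fused ring, leaves the unbound fraction within the scatter of the parent, though nothing measured alongside this result offers an explanation for it.

On these data alone, this single pair says nothing about how other groups behave at the same place, so it remains open whether an amine or a methoxy group on this aromatic carbon would give a step beyond the scatter. As far as these compounds go, it also remains open whether hydroxymethyl would give a similar step on other carbons of this ring, or in a compound that carries the oxadiazolone-type partner and cyclopropylmethyl group of compound 3 instead of the butyl chain and tetrazole-type partner of compound 2.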